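The source may report more compounds than this note shows. Statements on the series, on what has been measured and on what is new or still open speak of the compounds shown alone.

In a functional assay for activation of Alpha-1B adrenergic receptor (Homo sapiens), read by calcium flux (a lower number here means that less compound is needed, a higher number that more compound is needed for the effect), the three measured compounds gave:

Compound 1 `c1coc(-c2ccccc2NCC2=NCCN2)c1`: 6.31 nM
Compound 2 `Cc1cc(-c2ccccc2NCC2=NCCN2)on1`: 95.5 nM
Compound 3 `Cc1ccsc1-c1ccccc1NCC1=NCCN1`: 112 nM

Compound 1 stands lowest of the three. Both replacements of its furan-2-yl by a methylated five-membered heteroaryl raised the number sharply: a 15-fold higher number from compound 1 to compound 2 (1.18 log units; beyond the scatter) and an 18-fold higher number from compound 1 to compound 3 (1.25 log units; beyond the scatter), while the two replacements themselves differ only by a 1.2-fold higher number from compound 2 to compound 3 (0.07 log units; within the scatter). Compound 4 `Cc1nc(-c2ccccc2NCC2=NCCN2)no1` differs from compound 1 in one place: 5-methyl-1,2,4-oxadiazol-3-yl in place of furan-2-yl on an aromatic carbon. This is a third such replacement of furan-2-yl, so the two large steps from compound 1 bear directly on it, and a similar large rise is expected, a 24-fold higher number from compound 1 to compound 4 (1.38 log units; beyond the scatter). Compound 4 is therefore estimated at 150 nM, with a range from 40 nM to 600 nM.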

Compound 4, half-maximal effective concentration: 676 nM
For compound 4 the middle estimate is 4.5-fold (0.65 log units) below the measured one; measured number outside the range, above it.
By their numbers in this assay, from the lowest: compound 1; then compounds 2 and 3 (each within the scatter of the next); then compound 4.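

In this assay, the large rise seen at this position is not a single shared level for methylated five-membered heteroaryl groups: a 110-fold higher number from compound 1 to compound 4 (2.03 log units; beyond the scatter) goes well beyond the two earlier replacements. 5-Methyl-1,2,4-oxadiazol-3-yl, with its three ring hetero atoms, separates from both of them, by a 6.0-fold higher number from compound 3 to compound 4 (0.78 log units; beyond the scatter) and by a 7.1-fold higher number from compound 2 to compound 4 (0.85 log units; beyond the scatter). Nothing measured here accounts for this further rise. Going by these compounds, it remains open how much of the change belongs to the methyl group and how much to the ring, and whether an unmethylated 1,2,4-oxadiazol-3-yl, a phenyl or an amine here would lie nearer compound 1 or compound 4.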